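Methoxy in place of methylsulfanyl on a shared core

The source may hold more compounds than are shown below. What is called first, only, known or untested is meant among the compounds shown, and "the series" means these compounds.

In a functional assay on MDA-MB-435 cells (Homo sapiens) for inhibition, read by sulforhodamine B assay, with a stated time of 48 h (a higher number here means a weaker inhibitor, a lower number a stronger inhibitor), compound 1 (`COc1ccc(N(C)c2nc(N)nc3c2CCC3)cc1`) gives 16.7 nM and compound 2 (`CSc1ccc(N(C)c2ncnc3c2CCC3)cc1`) gives 42.8 nM, the higher of the two numbers, with a gap beyond the usual scatter. Compound 3 (`COc1ccc(N(C)c2ncnc3c2CCC3)cc1`) has methoxy in place of methylsulfanyl on an aromatic carbon, para to a large group (methoxy in place of methylsulfanyl on an aromatic carbon). Compound 1 also carries methoxy and gives 16.7 nM, but its core differs as well, so it offers only limited guidance. A modest move towards a lower number in this assay is expected, an estimated 3.1-fold lower number from compound 2 to compound 3 (0.49 log units; beyond the scatter). Compound 3 is expected at 14 nM, with an estimated range of 4 nM to 45 nM.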

Compound 3, half-maximal inhibitory concentration: 43 nM
The estimate for compound 3 lay 3.1-fold (0.49 log units) below the measured number; measured number inside the range.
By their numbers in this assay, from the lowest: compound 1; then compounds 2 and 3 (each within the scatter of the next).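

Methoxy in place of methylsulfanyl on an aromatic carbon, para to a large group, gives a 1.0-fold higher number from compound 2 to compound 3 (0.00 log units; within the scatter) in this assay, so the two groups are not told apart on this core. Hydrogen in place of amino on an aromatic carbon gives a 2.6-fold higher number from compound 1 to compound 3 (0.41 log units; beyond the scatter), which ties the lower number of compound 1 to its amino group rather than to its methoxy. No measurement offered here explains either step.

On these data alone, whether methylsulfanyl would match methoxy with the amino group present remains open. So does whether an ethoxy group or a chlorine atom would fit this position equally well.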